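Benzoate oxime esters: loss of the hydroxy toward compound 4

The source may hold more compounds than are shown below. What is called first, only, known or untested is meant among the compounds shown, and "the series" means these compounds.

Measured so far:
Compound 1 `COc1ccc(C2CC(=NOC(=O)c3ccccc3)CC(c3ccc(OC)cc3)N2C)cc1` gives 375000 nM in a functional assay, with a stated time of 30 min; on this read-out higher numbers stand for weaker inhibition and lower numbers for stronger inhibition.
Compound 2 `COc1ccc(C2CC(=NOC(=O)c3ccccc3OC(C)=O)CC(c3ccc(OC)cc3)N2C)cc1` gives 350000 nM.
Compound 3 `COc1ccc(C2CC(=NOC(=O)c3ccccc3O)CC(c3ccc(OC)cc3)N2C)cc1` gives 29000 nM.

Compound 3 holds the lowest number of the three. Both steps leading to it are large, a 13-fold lower number from compound 1 to compound 3 (1.11 log units; beyond the scatter) and a 12-fold lower number from compound 2 to compound 3 (1.08 log units; beyond the scatter), whereas a 1.1-fold lower number from compound 1 to compound 2 (0.03 log units; within the scatter) stays within the scatter. Compound 4 `COc1ccc(C(=O)ON=C2CC(c3ccc(OC)cc3)N(C)C(c3ccc(OC)cc3)C2)cc1` remains unmeasured; it differs from compound 3 by 4-methoxyphenyl in place of 2-hydroxyphenyl on a carbonyl carbon. The hydroxy present in compound 3 and absent in compound 1 is the only place where a large step has appeared, so its removal is the part of this change the measured steps bear on. Within the data shown here, the methoxy that enters has no measured counterpart here. The step is expected to be a 10-fold higher number from compound 3 to compound 4 (1.01 log units; beyond the scatter). Compound 4 is estimated at 300000 nM, between 100000 nM and 900000 nM.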

Compound 4, half-maximal inhibitory concentration: 68000 nM
Estimate against measurement, compound 4: 4.4-fold (0.64 log units) above, and the stated range ends above it.
By their numbers in this assay, from the lowest: compound 3; then compound 4; then compounds 2 and 1 (each within the scatter of the next).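

The methoxy that compound 4 carries and compound 1 lacks lowers the number (a 5.5-fold lower number from compound 1 to compound 4 (0.74 log units; beyond the scatter)), as does 4-methoxyphenyl in place of 2-acetoxyphenyl (a 5.1-fold lower number from compound 2 to compound 4 (0.71 log units; beyond the scatter)), so a lower number at this position does not require the hydroxy. With 4-methoxyphenyl in place of 2-hydroxyphenyl, the number rises only modestly (a 2.3-fold higher number from compound 3 to compound 4 (0.37 log units; beyond the scatter)), and compound 3 remains the lowest of the four. Nothing measured here explains these steps.

The compounds shown do not separate the identity of the group from its place on the ring. As far as these compounds go, how an amine, a carboxylic acid or a longer alkoxy chain would behave on this ring remains open.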